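A few compounds are considered here, and "the series" means these few. Any claim that something is new, unique, unknown or untested is made for them only; others in the source may bear on it.

Measured compounds:
- compound 1, `COc1cc2c(/C=C3/C(=O)Nc4ccc(O)cc43)c(Cl)n(Cc3cc(OC)c(OC)c(OC)c3)c2cc1C`: 1410 nM
- compound 2, `O=C1/C(=C/c2c(Cl)[nH]c3ccccc23)c2ccccc2N1Cc1ccccc1`: 2950 nM
- compound 3, `COc1c(/C=C2/C(=O)Nc3ccccc32)c2ccccc2n1-c1ccccc1`: 520 nM

All three compounds share a common core and were tested in a functional assay on cells (Leukemia cell, Homo sapiens) for cytotoxicity, with a stated time of 48 h; a lower number here means a stronger inhibitor of growth, a higher number a weaker inhibitor of growth. Among the three numbers, compound 1 stands second highest. Its closest neighbour is compound 2, whose number is higher, and that gap lies beyond the usual scatter of repeat measurements. Compound 3 gives the lowest number of the three, and its distance from compound 1 is also beyond the scatter. Among the measured compounds shown here, compound 1 therefore sits between a weaker and a stronger growth inhibitor, with no second measured compound that differs from it in only one place.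

The compound not yet measured is compound 4, `COc1ccc2c(c1)/C(=C\c1c(Cl)n(Cc3cc(OC)c(OC)c(OC)c3)c3cc(C)c(OC)cc13)C(=O)N2`. It differs from compound 1 by a single change: methyl in place of hydrogen on an oxygen on an aromatic ring. For the measured compounds named here, no pair of measured compounds shows this change on its own, so its effect here cannot be read off directly. The change is small in size, adds no hydrogen-bond donor or acceptor and carries no charge. The step of a 1.1-fold higher number from compound 1 to compound 4 (0.05 log units; within the scatter) is expected to be modest, perhaps within the scatter, with no strong reason to expect a move in either direction. Compound 4 is therefore estimated to come out near 1600 nM, within a range from 600 nM to 4500 nM.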

Compound 4, concentration for 50% growth inhibition: 6170 nM
For compound 4 the middle estimate is 3.9-fold (0.59 log units) below the measured one, and the stated range ends below it.
By their numbers in this assay, from the lowest: compound 3; then compound 1; then compound 2; then compound 4.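

In this assay the change from hydroxy to methoxy brings a 4.4-fold higher number from compound 1 to compound 4 (0.64 log units; beyond the scatter) and so shows that this spot on the aromatic ring responds to the addition of a single carbon. The earlier compounds shown here differed from one another in several places at once, so they could not isolate any one position; this pair now does, and the hydroxy form is the stronger growth inhibitor of the two. That finding holds for this one pair on this one core, and nothing measured here explains why the number rises.

The compounds shown leave open whether the same change would have a similar effect on a different core, since no other pair carries it alone. They also leave open how an amine, a carboxylic acid or an ethoxy group in this place on the aromatic ring would compare with hydroxy and methoxy, and so whether the trend continues with larger groups or depends on the hydrogen of the hydroxy group.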